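Working notes: 2-fluorobenzyl to 2-chlorobenzyl

A few compounds are considered here, and "the series" means these few. Any claim that something is new, unique, unknown or untested is made for them only; others in the source may bear on it.

- compound 1 `O=[N+]([O-])c1cc(C(F)(F)F)cc([N+](=O)[O-])c1Oc1c(Br)cc(Br)cc1/C=N\OCc1ccccc1`: 2150 nM
- compound 2 `O=[N+]([O-])c1cc(C(F)(F)F)cc([N+](=O)[O-])c1Oc1c(Br)cc(Br)cc1/C=N\OCc1ccccc1F`: 1560 nM

Within the data shown here, in a functional assay on A549 cells (Homo sapiens) for antiproliferative activity, read by MTT assay, with a stated time of 48 h (a lower number here means a stronger inhibitor, a higher number a weaker inhibitor), compound 2 gives 1560 nM, the lower of only two numbers, but within the scatter of the other. Compound 3 `O=[N+]([O-])c1cc(C(F)(F)F)cc([N+](=O)[O-])c1Oc1c(Br)cc(Br)cc1/C=N\OCc1ccccc1Cl` carries chloro in place of fluoro on an aromatic carbon, ortho to a large group: chloro in place of fluoro on an aromatic carbon. Among the measured compounds shown here, the one measured step at this carbon, a 1.4-fold lower number from compound 1 to compound 2 (0.14 log units; within the scatter), is small, and no chloro compound has been measured yet. No change beyond the scatter is therefore expected. The expected step is a 1.1-fold lower number from compound 2 to compound 3 (0.05 log units; within the scatter). For compound 3 the estimated value is 1400 nM, with an expected range of 750 nM to 2600 nM.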

Compound 3, half-maximal inhibitory concentration: 4120 nM
Beside the measured number, compound 3's estimate is 2.9-fold (0.47 log units) below it, outside the stated range (above it).
By their numbers in this assay, from the lowest: compounds 2, 1 and 3 (each within the scatter of the next, the first and the last beyond it).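

In this assay, among these compounds, this position distinguishes between the two halogens: a 2.6-fold higher number from compound 2 to compound 3 (0.42 log units; beyond the scatter) lies beyond the scatter and is the only such step. Against the unsubstituted benzyl, a 1.9-fold higher number from compound 1 to compound 3 (0.28 log units; within the scatter) stays within the scatter, so the 2-fluorobenzyl and 2-chlorobenzyl compounds separate from each other but neither separates from compound 1. Nothing on hand accounts for the gap between the two halogens.

Going by these compounds, whether bromo or methoxy at this carbon would fall within the same span remains open. So does whether the change from fluoro to chloro gives a similar step on another carbon of this ring.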